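Methoxy Addition on a Repositioned Side Chain

The source may hold more compounds than are shown below. What is called first, only, known or untested is meant among the compounds shown, and "the series" means these compounds.

Three compounds share a large core and differ in where a side chain sits. Compound 1 `COc1ccc(C(=O)Nc2ccc(C)c(Nc3nccc(-c4cccnc4)n3)c2)cc1OCCCCn1ccnc1`, compound 2 `Cc1ccc(NC(=O)c2cccc(OCCCCn3ccnc3)c2)cc1Nc1nccc(-c2cccnc2)n1` and compound 3 `Cc1ccc(NC(=O)c2ccc(OCCCCn3ccnc3)cc2)cc1Nc1nccc(-c2cccnc2)n1` were tested in a functional assay on K-562R cells (Homo sapiens) for cytotoxicity, read by XTT assay, with a stated time of 24 h; a higher number here means a weaker inhibitor, a lower number a stronger inhibitor. In this assay compound 1 gives 18700 nM, compound 2 gives 63400 nM and compound 3 gives 99400 nM. The difference between the cores of compound 2 and compound 3 is not broken down here. The step of a 3.4-fold lower number from compound 2 to compound 1 (0.53 log units; beyond the scatter) came with methoxy in place of hydrogen on an aromatic carbon. Compound 4 `COc1cc(C(=O)Nc2ccc(C)c(Nc3nccc(-c4cccnc4)n3)c2)ccc1OCCCCn1ccnc1` is not yet measured; it differs from compound 3 by methoxy in place of hydrogen on an aromatic carbon, the same kind of change, though the place is meta to a large group rather than para. Because the earlier step was a 3.4-fold lower number from compound 2 to compound 1 (0.53 log units; beyond the scatter), a step of similar size is expected, a 2.8-fold lower number from compound 3 to compound 4 (0.45 log units; beyond the scatter). Compound 4 is therefore estimated at 35000 nM, within a range from 15000 nM to 90000 nM.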

Compound 4, half-maximal inhibitory concentration: 27100 nM
Beside the measured number, compound 4's estimate is 1.3-fold (0.11 log units) above it; low and high end bracket the measured number.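

Putting methoxy in place of hydrogen on an aromatic carbon gave a 3.7-fold lower number from compound 3 to compound 4 (0.56 log units; beyond the scatter) in this assay, and the same change has now lowered the number on two cores by a matching amount: the same change on two cores in this assay, a 3.4-fold lower number (0.53 log units; beyond the scatter) from compound 2 to compound 1 and a 3.7-fold lower number (0.56 log units; beyond the scatter) from compound 3 to compound 4, 1.1-fold (0.03 log units) apart, within the scatter of two such steps

Within these two pairs, then, the step carried from one core to the other with its size intact. Two pairs do not show that it would hold on other cores in the series, and they do not explain why methoxy lowers the number.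

The compounds shown leave open whether an ethoxy group or a fluorine atom at the same place would give a similar step. They also leave open whether the step would survive if a shorter chain replaced the 4-(1H-imidazol-1-yl)butoxy group.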